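The source may hold more compounds than are shown below. What is called first, only, known or untested is meant among the compounds shown, and "the series" means these compounds.

Series notes. Compound 1 `O=C(Nc1cccc(-n2cc(-c3ccncc3)c(-c3ccc(Cl)c(O)c3)n2)c1)Nc1ccc(Cl)c(Cl)c1` in a functional assay on HCT-116 cells (Homo sapiens) for inhibition, read by sulforhodamine B assay, with a stated time of 48 h (a higher number here means that more compound is tolerated, a lower number that less compound is tolerated), reaches only a limit, > 32500 nM. Compound 2 `O=C(Nc1cccc(-n2cc(-c3ccncc3)c(-c3ccc(Cl)c(O)c3)n2)c1)Nc1cc(C(F)(F)F)cc(C(F)(F)F)c1` in this assay gives 2650 nM. Compound 3 `COc1cc(-c2nn(-c3cccc(NC(=O)Nc4cccc(C(F)(F)F)c4)c3)cc2-c2ccncc2)ccc1Cl` in this assay also sits at a limit, > 50000 nM, so it stands only as a bound (the limit of > 50000 nM in this assay, at which 1 of the 3 values shown sits). Compound 1 likewise stands at a bound (the limit of > 32500 nM in this assay, at which 1 of the 3 values shown sits).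

Compound 4 `O=C(Nc1cccc(-n2cc(-c3ccncc3)c(-c3ccc(Cl)c(O)c3)n2)c1)Nc1cccc(C(F)(F)F)c1` differs from compound 3 by hydrogen in place of methyl on an oxygen on an aromatic ring. Within the data shown here, no measured pair shows this change on its own. Compound 2 carries the same hydroxy group and gives a number where compound 3 and compound 1 do not. On that basis, in this assay the step of an at least 4.1-fold lower number from compound 3 to compound 4 (0.61 log units; beyond the scatter) is expected to run downward, probably beyond the scatter. The estimate for compound 4 in this assay is 12000 nM, within 3000 nM to 50000 nM.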

Compound 4, concentration lethal to 50% of the cells: > 32500 nM
Compound 4 gave a limit, no number; the forecaster's own chance of this, stated with the estimate: 35%; middle value at least 2.7-fold (0.43 log units) away from the limit.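

In this assay, among these compounds, hydrogen in place of trifluoromethyl on an aromatic carbon gives an at least 12-fold higher number from compound 2 to compound 4 (1.08 log units; beyond the scatter), the first single-place change that can be read. The hydroxy group alone therefore does not secure a number in this series, as compound 4 carries it and still stands at a limit. The steps to compound 4 from compound 3 and from compound 1 cannot be read, because both ends of each are limits: the limit of > 32500 nM in this assay, at which 2 of the 4 values shown sit.

Among the compounds shown here, the effect of methoxy to hydroxy remains open, as no pair with numbers at both ends shows it. Also open, as far as these compounds go, is how an amine or a carboxylic acid in place of that trifluoromethyl would read in this assay.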